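A few compounds are considered here, and "the series" means these few. Any claim that something is new, unique, unknown or untested is made for them only; others in the source may bear on it.

Measured in a functional assay on HL-60 cells (Homo sapiens) for antiproliferative activity, with a stated time of 72 h; on this read-out lower numbers stand for stronger inhibition and higher numbers for weaker inhibition:
- compound 1 `COc1ccccc1CNc1ncnc2c1ncn2[C@@H]1O[C@H](CO)[C@@H](O)[C@H]1O`: 2300 nM
- compound 2 `COc1ccc(CNc2ncnc3c2ncn3[C@@H]2O[C@H](CO)[C@@H](O)[C@H]2O)c(OC)c1`: 39000 nM

Compound 2 has the higher number of the pair, so it is the less active one here. Compound 3 `OC[C@H]1O[C@@H](n2cnc3c(NCc4ccc(F)c(F)c4F)ncnc32)[C@H](O)[C@@H]1O` changes it as follows: 2,3,4-trifluorophenyl in place of 2,4-dimethoxyphenyl on a saturated chain carbon bound to a nitrogen on an aromatic ring. Among the compounds with values here, the one measured step that bears on this is a 17-fold higher number from compound 1 to compound 2 (1.23 log units; beyond the scatter), a large step that came with methoxy in place of hydrogen on an aromatic carbon. Within the data shown here, compound 3 carries no methoxy, so a lower number is expected, although no measured step covers fluorine. The expected step, somewhat smaller than that one, is a 4.9-fold lower number from compound 2 to compound 3 (0.69 log units; beyond the scatter). Compound 3 is estimated at 8000 nM, with an expected range of 1500 nM to 40000 nM.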

Compound 3, half-maximal inhibitory concentration: 13000 nM
For compound 3 the middle estimate is 1.6-fold (0.21 log units) below the measured one, and the stated range covers the measured number.
By their numbers in this assay, from the lowest: compound 1; then compound 3; then compound 2.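

In this assay, 2,3,4-trifluorophenyl in place of 2,4-dimethoxyphenyl gives a 3.0-fold lower number from compound 2 to compound 3 (0.48 log units; beyond the scatter), so this position tolerates a ring with no methoxy and regains part of the earlier loss. In place of 2-methoxyphenyl, the same ring gives a 5.7-fold higher number from compound 1 to compound 3 (0.75 log units; beyond the scatter), so it does not match the ring with a single methoxy. No measurement at hand offers an explanation for these differences. Still open, on these data alone, is how an unsubstituted phenyl ring, a single fluorine or a pyridine ring would compare here.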